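A few compounds are considered here, and "the series" means these few. Any claim that something is new, unique, unknown or untested is made for them only; others in the source may bear on it.

In a functional assay on OVCAR-3 cells (Homo sapiens) for inhibition, read by MTT assay, with a stated time of 24 h (on this read-out higher numbers stand for weaker inhibition and lower numbers for stronger inhibition), two compounds with the same core have been measured so far. Compound 1 `CC1(C)[C@H]2CC[C@]1(C)N(Cc1cn(-c3ccccc3)nn1)C(=O)C2` carries a plain phenyl group and gives 50 nM. Compound 2 `CC1(C)[C@H]2CC[C@]1(C)N(Cc1cn(-c3cccc(Br)c3)nn1)C(=O)C2` carries a 3-bromophenyl group instead and gives 30 nM. These two values lie within the scatter of each other, so compound 2 stands level with compound 1 on the numbers available.

Compound 3 `Cc1cccc(-n2cc(CN3C(=O)C[C@@H]4CC[C@@]3(C)C4(C)C)nn2)c1` differs from compound 2 at a single place: methyl in place of bromo on an aromatic carbon. Put simply, this is methyl in place of bromo on an aromatic carbon, turning 3-bromophenyl into 3-methylphenyl. Among the measured compounds shown here, no measured compound carries this methyl group, so there is no direct evidence for it. For the measured compounds named here, the only measured change on this ring is bromo in place of hydrogen, and that gave a 1.7-fold lower number from compound 1 to compound 2 (0.22 log units; within the scatter). Going by the values given here, with so small a step as the sole guide, no shift beyond the scatter is expected in this assay, and no direction can be firmly called. The expected change is small, estimated as a 1.3-fold higher number from compound 2 to compound 3 (0.12 log units; within the scatter). For compound 3 the estimated value is 40 nM, with an expected range from 15 nM to 100 nM.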

Compound 3, half-maximal inhibitory concentration: 160 nM
Compound 3: the middle estimate sits 4.0-fold (0.60 log units) below what was measured; the whole stated range lies below it.
By their numbers in this assay, from the lowest: compounds 2 and 1 (each within the scatter of the next); then compound 3.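

In this assay, this place on the ring proves to be sensitive to what sits there: replacing bromo with methyl gives a 5.3-fold higher number from compound 2 to compound 3 (0.73 log units; beyond the scatter), even though each group counts as a single heavy atom and the earlier change from hydrogen to bromo stayed within the scatter. Methyl also separates from hydrogen, with a 3.2-fold higher number from compound 1 to compound 3 (0.51 log units; beyond the scatter), so among the three groups shown, methyl is the one that stands apart, while hydrogen and bromo remain level with each other. Nothing available explains why this small exchange moves the number so clearly.

On these data alone, whether a chloro or methoxy group or an amine at this same place would stay level with hydrogen and bromo or follow methyl to a higher number remains open, as does what a longer chain such as ethyl would do. The compounds also cover only this one place on the ring, so they cannot say whether methyl elsewhere on the ring would give a similar step.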